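Fluoro for hydrogen on the pendant phenyl in two cores

This account rests on a few compounds, and the source may have more. Where it says the series, first, only, none or still open, it means among the compounds named here.

Compound 1 `c1ccc(Cc2[nH]cnc3ncnc2-3)cc1` and compound 2 `Fc1ccc(Cc2[nH]cnc3ncnc2-3)cc1` share one core. In an assay on isolated protein for inhibition of Ca2+/calmodulin-dependent protein kinase II (CaM kinase II) (Rattus norvegicus), tested at 30 uM (a higher number here means more inhibition at the concentration tested (going by the name of the read-out), a lower number less inhibition), compound 1 gives 2% and compound 2 gives 8%. The change between them is fluoro in place of hydrogen on an aromatic carbon and it made a number 6 percentage points higher from compound 1 to compound 2 (within the scatter). Compound 3 `Cn1c(-c2ccc([S+](C)[O-])cc2)nc2c(Sc3ccccc3)ncnc21` is built on another core; the difference between the two cores is not broken down here. In this assay compound 3 gives 8%, level with compound 2 at the digits reported. Compound 4 `Cn1c(-c2ccc([S+](C)[O-])cc2)nc2c(Sc3ccc(F)cc3)ncnc21` has not been measured in this assay. It differs from compound 3 by fluoro in place of hydrogen on an aromatic carbon, the same change as between compound 1 and compound 2, the two place descriptions agreeing word for word. Expected is a number 2 percentage points higher from compound 3 to compound 4 (within the scatter), because a number 6 percentage points higher from compound 1 to compound 2 (within the scatter) stayed within the scatter and because compound 3 gives 8% as the starting point. Whether the second core answers the change as the first did rests on that single measured step alone, so the range is kept wide. Compound 4 is estimated at 10%, between 0% and 25%.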

Compound 4, a percentage reported as inhibition, at one concentration (the size of the read-out at that concentration, not a potency): 12%
Compound 4: the middle estimate sits 2 percentage points below what was measured; measured number inside the range.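

In this assay, phenylsulfanyl to (4-fluorophenyl)sulfanyl gave a number 4 percentage points higher from compound 3 to compound 4 (within the scatter). Set beside the earlier step, the same change reads alike on the two cores: the same change on two cores in this assay, a number 6 percentage points higher (within the scatter) from compound 1 to compound 2 and a number 4 percentage points higher (within the scatter) from compound 3 to compound 4, 2 percentage points apart, within the scatter of two such steps. This shows that, for this pair of cores, the step on one core gave a fair guide to the step on the other, but only for a change that stays within the scatter on both; it does not show that fluoro raises inhibition on either core, and it does not show that a step beyond the scatter would carry from one core to the other.

The compounds shown leave open whether another group at the same place on the ring, such as chloro, methoxy, an amine or a carboxylic acid, would move the read-out beyond the scatter. Also open, as far as these compounds go, is whether a longer chain in place of the methyl group of compound 3 would alter the response to fluoro.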